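The source may hold more compounds than are shown below. What is called first, only, known or untested is meant among the compounds shown, and "the series" means these compounds.

In an ADME assay on DU-145 cells (Homo sapiens) for cytotoxicity, read by MTT assay, with a stated time of 72 h (on this read-out lower numbers stand for stronger inhibition and higher numbers for weaker inhibition), compound 1 `COC(=O)c1cc(C2=C(c3cc(OC)c(OC)c(OC)c3)C(=O)CC2O[SiH2]C(C)(C)C)ccc1OC` gives > 100 ug/mL, and this is a limit of the assay rather than a measured number. Compound 1 therefore stands at the limit of > 100 ug/mL in this assay, at which 1 of the 2 values shown sits, so the cytotoxic strength of compound 1 is known only as being weaker than that limit. Compound 2 `COc1ccc(C2=C(c3cc(OC)c(OC)c(OC)c3)C(=O)C(O)C2)cc1Cl` gives 40 ug/mL in this assay. No step between compound 1 and compound 2 is computed, so these two values can only be set side by side, and nothing in them points to a cause.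

Compound 3 `COc1cc(C2=C(c3cc(C)c(OC)c(C)c3)C(O[SiH2]C(C)(C)C)CC2=O)cc(OC)c1OC` has not yet been measured. It differs from compound 1 in one place: 4-methoxy-3,5-dimethylphenyl in place of 4-methoxy-3-(methoxycarbonyl)phenyl on a double-bonded ring carbon. The size of the step from compound 1 to compound 3 cannot be pinned down from data; the expected step is an at least 1.2-fold lower number from compound 1 to compound 3 (0.09 log units; that floor lies within the scatter), a modest move toward stronger inhibition that may not exceed the usual scatter. Compound 3 is estimated at 80 ug/mL, with a range from 30 ug/mL to 200 ug/mL, and a real chance that this assay again reports only a limit.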

Compound 3, half-maximal inhibitory concentration: > 100 ug/mL
Compound 3 was reported as a limit; the forecaster's own chance of this, stated with the estimate: 45%; middle value at least 1.2-fold (0.09 log units) from the limit.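

In this assay compound 3 gives > 100 ug/mL, a limit of the assay and not a number. Among the compounds shown here, compound 1 also gives only a limit, so no step between compound 1 and compound 3 can be read: the limit of > 100 ug/mL in this assay, at which 2 of the 3 values shown sit. As far as these compounds go, whether 4-methoxy-3,5-dimethylphenyl in place of 4-methoxy-3-(methoxycarbonyl)phenyl changes cytotoxic strength at all remains open.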